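Methoxy for trifluoromethyl on a benzoxazole-free sulfonamide series

This account rests on a few compounds, and the source may have more. Where it says the series, first, only, none or still open, it means among the compounds named here.

Measured compounds:
- compound 1, `O=S(=O)(Nc1ccc(-c2nc3ccccc3o2)cc1)c1ccc(Cl)s1`: in an assay on isolated protein for inhibition of malate dehydrogenase, mitochondrial (Sus scrofa), with stated times of 45 min and 30 min (on this read-out lower numbers stand for stronger inhibition and higher numbers for weaker inhibition), compound 1 gives > 63000 nM, a limit of the assay and not a number.
- compound 2, `COc1ccccc1S(=O)(=O)Nc1ccc(-c2nc3ccccc3o2)cc1`: in this assay compound 2 gives > 63000 nM, again a limit.
- compound 3, `O=S(=O)(Nc1ccc(-c2nc3ccccc3o2)cc1)c1ccc(C(F)(F)F)cc1`: in this assay compound 3 gives > 63000 nM, also a limit.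

Compound 3 thus stands at the same limit as every other measured compound; no number separates it from the rest. For the measured compounds named here, the one measured step, a step that the two limits leave unreadable from compound 1 to compound 2, runs between two limits and its size cannot be read. All that is known is the limit of > 63000 nM in this assay, at which 3 of the 3 values shown sit.

Compound 4, `COc1ccc(S(=O)(=O)Nc2ccc(-c3nc4ccccc4o3)cc2)cc1`, differs from compound 3 by methoxy in place of trifluoromethyl on an aromatic carbon. Going by the values given here, no measured step bears directly on this exchange. Among the compounds with values here, the only related point is compound 2, which carries a methoxy on its sulfonyl-side ring and sits at the limit. The expectation for this assay is therefore no step beyond the scatter, with the value of compound 4 most likely reported again as a limit; the estimated step that the limit leaves unreadable from compound 3 to compound 4 is essentially flat. Compound 4 is estimated at 100000 nM, within 30000 nM to 400000 nM.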

Compound 4, half-maximal inhibitory concentration: > 63000 nM
Compound 4: only a limit was reported; the forecaster's own chance of this, stated with the estimate: 85%; the middle value does not contradict the limit.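

In this assay, the steps from compound 1, compound 2 and compound 3 to compound 4 cannot be read, as every value is a limit and not a number: the limit of > 63000 nM in this assay, at which 4 of the 4 values shown sit.

The compounds shown leave open whether any group on the sulfonyl sulfur gives a readable value in this assay, and how these four compare.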